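Amide cap variation on the shared core

This account rests on a few compounds, and the source may have more. Where it says the series, first, only, none or still open, it means among the compounds named here.

The series keeps one core and varies the group on the amide carbonyl. Compound 1 `N#Cc1ccc(C(=O)Nc2cccc(NC(=O)COc3ccc4c(=O)ccoc4c3)c2)cc1` carries a 4-cyanophenyl there; in an assay on isolated protein for inhibition of Rho-associated protein kinase 2 (Homo sapiens), read by scintillation counting, radiometric assay and 33P incorporation, with a stated time of 40 min, in the presence of a further agent that is not named here (on this read-out lower numbers stand for stronger inhibition and higher numbers for weaker inhibition), compound 1 gives 15 nM. Within the data shown here, compound 2 `CC(C)(C)c1cc(C(=O)Nc2cccc(NC(=O)COc3ccc4c(=O)ccoc4c3)c2)no1` carries a 5-(tert-butyl)-1,2-oxazol-3-yl; in this assay compound 2 gives 5 nM, the lowest of the two numbers measured so far, and the step of a 3.0-fold lower number from compound 1 to compound 2 (0.48 log units; beyond the scatter) lies beyond the scatter. Compound 3 `Nc1cccc(C(=O)Nc2cccc(NC(=O)COc3ccc4c(=O)ccoc4c3)c2)c1` is not yet measured; the change from compound 2 is 3-aminophenyl in place of 5-(tert-butyl)-1,2-oxazol-3-yl on a carbonyl carbon. Among the measured compounds shown here, the only measured step that bears on this is a 3.0-fold lower number from compound 1 to compound 2 (0.48 log units; beyond the scatter), in which the phenyl amide stands at the higher number and the oxazole amide at the lower. Because a 3.0-fold lower number from compound 1 to compound 2 (0.48 log units; beyond the scatter) placed the phenyl amide higher, compound 3 is expected to move back up by a modest amount, a 3.0-fold higher number from compound 2 to compound 3 (0.48 log units; beyond the scatter). Compound 3 is estimated at 15 nM, with a range of 5 nM to 50 nM.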

Compound 3, half-maximal inhibitory concentration: 58 nM
Estimate against measurement, compound 3: 3.9-fold (0.59 log units) below, outside the stated range (above it).
By their numbers in this assay, from the lowest: compound 2; then compound 1; then compound 3.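

In this assay, among these compounds, this position proves more sensitive than the first comparison showed: a 12-fold higher number from compound 2 to compound 3 (1.06 log units; beyond the scatter) is a large step, the widest of the series so far. The two caps with a six-membered aromatic ring of carbon only also differ from each other, with a 3.9-fold higher number from compound 1 to compound 3 (0.59 log units; beyond the scatter), so the earlier contrast between a phenyl amide and an oxazole amide does not by itself set the number. What is attached to the phenyl ring, and where, therefore counts at this carbonyl carbon, although 3-aminophenyl and 4-cyanophenyl differ in both respects at once.

The compounds shown do not separate these two changes, which a 4-aminophenyl or 3-cyanophenyl cap would do, and they do not show how a 3-(dimethylamino)phenyl or 3-carboxyphenyl cap would read. No measurement among the data explains why the 3-aminophenyl cap gives the highest number.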